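Removing a Methyl from a Biphenyl Sulfonamide: Cytotoxicity Outlook

A few compounds are considered here, and "the series" means these few. Any claim that something is new, unique, unknown or untested is made for them only; others in the source may bear on it.

Compound 2 `Cc1ccc(-c2ccccc2S(=O)(=O)N2CCC(N3CCC(C)CC3)CC2)cc1` stands only at a limit in an ADME assay on HCT-116 cells (Homo sapiens) for cytotoxicity, read by CellTiter-Glo, with a stated time of 72 h; on this read-out higher numbers stand for weaker inhibition and lower numbers for stronger inhibition: compound 2 gives > 5000 nM. Compound 1 `Cc1cc(C)c(S(=O)(=O)N2CCC(C3OCC(C)CO3)CC2)c(C)c1` gives > 5000 nM, a limit. Compound 3 `Cc1cc(C)c(S(=O)(=O)N2CCC(N3CCC(CCO)CC3)CC2)c(C)c1` gives > 5000 nM, again a limit. Going by the values given here, the single step that joins two measured compounds, a step that the two limits leave unreadable from compound 1 to compound 3, cannot be read because of the limit of > 5000 nM in this assay, at which 3 of the 3 values shown sit. Compound 4 `CC1CCN(C2CCN(S(=O)(=O)c3ccccc3-c3ccccc3)CC2)CC1` differs from compound 2 by hydrogen in place of methyl on an aromatic carbon. Among the compounds with values here, no measured step bears on this change, and no measured step in this set has a readable size, so nothing points to a shift beyond the scatter in this assay. Compound 4 is therefore expected to sit at 10000 nM, within 4000 nM to 50000 nM, most likely reported once more only as a limit, the expected step being a step that the limit leaves unreadable from compound 2 to compound 4.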

Compound 4, half-maximal inhibitory concentration: > 5000 nM
Compound 4: no number, only a limit; the forecaster's own chance of this, stated with the estimate: 85%; the middle value does not contradict the limit.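

The step from compound 2 to compound 4 cannot be read in this assay, because both compounds stand only at a limit: the limit of > 5000 nM in this assay, at which 4 of the 4 values shown sit.

The compounds shown leave open whether going from 4-methylphenyl to phenyl changes the read-out at all.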